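Pyrrolyl in Place of Methyl: What to Expect for Compound 4

The compounds below may be only part of what the source reports. "The series", "measured", "known", "first", "only" and "open" are said of these compounds alone.

Compound 1 `COC(=O)c1nc(C)n(-c2ccccc2)n1`: in a functional assay on NPC-TW01 cells (Homo sapiens) for inhibition, read by MTT assay, with a stated time of 72 h (on this read-out higher numbers stand for weaker inhibition of growth and lower numbers for stronger inhibition of growth), compound 1 gives only a limit of the assay, > 100000 nM.
Compound 2 `COC(=O)c1nc(C)n(-c2ccc(C(F)(F)F)cc2)n1`: in this assay compound 2 also gives only a limit of the assay, > 100000 nM.
Compound 3 `COC(=O)c1nc(C)n(-c2ccc(F)cc2)n1`: in this assay compound 3 gives a number, 15200 nM.

Compound 2 thus stands at the limit of > 100000 nM in this assay, at which 2 of the 3 values shown sit, and with compound 1 at the same limit the step that the two limits leave unreadable from compound 1 to compound 2 cannot be sized. For the measured compounds named here, the one readable change is an at least 6.5-fold lower number from compound 2 to compound 3 (0.81 log units; beyond the scatter), and likewise an at least 6.5-fold lower number from compound 1 to compound 3 (0.81 log units; beyond the scatter). Compound 4 `COC(=O)c1nc(-c2ccc[nH]2)n(-c2ccc(C(F)(F)F)cc2)n1` differs from compound 2 by 1H-pyrrol-2-yl in place of methyl on an aromatic carbon. Going by the values given here, none of the measured steps touches that place; all three alter only the group on the phenyl ring, so no measured step bears on this change. Compound 2 itself is known only as a limit, which leaves the expected size of the step from compound 2 to compound 4 in this assay open in either direction. Compound 4 is therefore estimated at 100000 nM, within a wide range from 15000 nM to 300000 nM, most likely again reported as a limit. This estimate amounts to an expected a number no higher from compound 2 to compound 4 (the limit leaves the size open).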

Compound 4, concentration for 50% growth inhibition: > 100000 nM
Compound 4 gave a limit, no number; the forecaster's own chance of this, stated with the estimate: 65%; the middle value lies on the limit itself.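

In this assay, for the compounds shown here, compound 4, like compound 2, gives only a limit of the assay, so no step between compound 2 and compound 4 can be read: the limit of > 100000 nM in this assay, at which 3 of the 4 values shown sit.
The compounds shown leave open whether 1H-pyrrol-2-yl in place of methyl changes growth inhibition at all, and in which direction.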